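A few compounds are considered here, and "the series" means these few. Any claim that something is new, unique, unknown or untested is made for them only; others in the source may bear on it.

Working notes on the series. Compound 1 `Nc1cc(N)c2nc(-c3ccccc3)c(Oc3ccc(Cl)c(Cl)c3)nc2c1` and compound 2 `Nc1cc(N)c2nc(-c3ccccc3)c(NCc3ccc(Cl)c(Cl)c3)nc2c1` share the core and differ in the link to the 3,4-dichlorophenyl unit. In a functional assay on NCI/ADR-RES cells (Homo sapiens) for inhibition, read by sulforhodamine B assay, with a stated time of 48 h (a lower number here means that less compound is tolerated, a higher number that more compound is tolerated), compound 1 gives only a limit, < 100000 nM. In this assay compound 2 likewise gives only a limit, < 100000 nM. Both values sit at the limit of < 100000 nM in this assay, at which 2 of the 2 values shown sit, so compound 2 cannot be ranked against compound 1 on the numbers at hand. Compound 3 `Nc1cc(N)c2nc(-c3ccccc3)c(NCc3ccc(F)cc3)nc2c1` differs from compound 2 by 4-fluorophenyl in place of 3,4-dichlorophenyl on a saturated chain carbon bound to a nitrogen on an aromatic ring. Going by the values given here, no measured step frames this change, and the expected step that the limit leaves unreadable from compound 2 to compound 3 is none beyond the scatter. Compound 3 is estimated at 40000 nM, with a range from 5000 nM to 100000 nM, and is expected most likely to give only a limit again.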

Compound 3, concentration lethal to 50% of the cells: 28200 nM
Beside the measured number, compound 3's estimate is 1.4-fold (0.15 log units) above it; the range from low to high includes it.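

No new step can be read for compound 3 against compound 1 or compound 2, as both of those give only limits in this assay: the limit of < 100000 nM in this assay, at which 2 of the 3 values shown sit. The compounds shown leave open how far either change at the link or on the benzyl group shifts the read-out.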